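Amine replacement two bonds from the aryl oxygen

This account rests on a few compounds, and the source may have more. Where it says the series, first, only, none or still open, it means among the compounds named here.

Within the data shown here, compound 1 `CC(C)=CCc1cc(C(=O)Nc2cc3ccc(OCCC4CCCCN4)c(C)c3oc2=O)ccc1O` is the only member of the series with a number in a functional assay on MCF7 cells (Homo sapiens) for antiproliferative activity; a lower number here means a stronger inhibitor, a higher number a weaker inhibitor: in this assay compound 1 gives 710 nM. Compound 2 `CC(C)=CCc1cc(C(=O)Nc2cc3ccc(OCCCNc4ccccc4)c(C)c3oc2=O)ccc1O` carries anilinomethyl in place of piperidin-2-yl on a saturated chain carbon, two bonds along the chain from an oxygen on an aromatic ring. In this assay compound 2 reaches only a limit of the assay, > 50000 nM. Among the measured compounds shown here, the step is an at least 70-fold higher number from compound 1 to compound 2 (1.84 log units; beyond the scatter); it is the one measured step that bears on the change at hand, and its end point is the limit of > 50000 nM in this assay, at which 1 of the 2 values shown sits.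

Compound 3 `CC(C)=CCc1cc(C(=O)Nc2cc3ccc(OCCCN(C)c4ccccc4)c(C)c3oc2=O)ccc1O` is not yet measured. It differs from compound 1 by (methyl(phenyl)amino)methyl in place of piperidin-2-yl on a saturated chain carbon, two bonds along the chain from an oxygen on an aromatic ring. This closely parallels the change seen in compound 2, so a step of similar size towards a weaker inhibitor is expected, a 56-fold higher number from compound 1 to compound 3 (1.75 log units; beyond the scatter). Compound 3 is estimated at 40000 nM, between 8000 nM and 200000 nM, with a fair chance that only a limit is reported.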

Compound 3, half-maximal inhibitory concentration: > 50000 nM
Compound 3 was reported as a limit; the forecaster's own chance of this, stated with the estimate: 55%; middle value at least 1.2-fold (0.09 log units) from the limit.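

In this assay, (methyl(phenyl)amino)methyl in place of piperidin-2-yl gives an at least 70-fold higher number from compound 1 to compound 3 (1.84 log units; beyond the scatter), so the large loss seen with the anilinomethyl group of compound 2 recurs when that nitrogen also carries methyl. The loss at this position is therefore not confined to the anilinomethyl group with its nitrogen hydrogen. The step from compound 2 to compound 3 cannot be read, and the methyl on the nitrogen has no measurable size here, only a shared limit rather than two numbers: the limit of > 50000 nM in this assay, at which 2 of the 3 values shown sit.

Going by these compounds, it remains open whether the loss follows the phenyl group on the nitrogen or the departure of the piperidine ring. A 3-(cyclohexylamino)propoxy or 3-(piperidin-1-yl)propoxy chain would separate these two readings, and a 3-(benzylamino)propoxy chain would test a phenyl group held one carbon away from the nitrogen.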